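The compounds below may be only part of what the source reports. "The series", "measured", "known", "first", "only" and "open" are said of these compounds alone.

Cytotoxicity in an ADME assay on MT2 cells (Homo sapiens) for cytotoxicity, read by MTT assay (on this read-out lower numbers stand for higher toxicity in this test and higher numbers for lower toxicity in this test), so far:
compound 1 `Fc1cccc(F)c1Cc1cnc(Nc2ccc(Oc3cccnc3)cc2)o1` — 22000 nM
compound 2 `Fc1cccc(F)c1Cc1cnc(Nc2ccc(Oc3cccnc3)c(Br)c2)o1` — 7500 nM
compound 3 `COCc1ccc(Nc2ncc(Cc3c(F)cccc3F)o2)cc1` — 32000 nM

Compound 1 gives the second highest of the three numbers in this assay. Its nearest neighbour lies within the scatter: a 1.5-fold higher number from compound 1 to compound 3 (0.16 log units; within the scatter). The furthest lies beyond it: a 2.9-fold lower number from compound 1 to compound 2 (0.47 log units; beyond the scatter).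

Compound 4 `O=c1ccn(CCOc2ccc(Nc3ncc(Cc4c(F)cccc4F)o3)cc2)c(=O)[nH]1` is not yet measured. Relative to compound 1 the change is a group of 10 heavy atoms (6 carbon, 2 nitrogen, 2 oxygen; one six-membered aromatic ring with 2 hetero atoms) in place of a group of 6 heavy atoms (5 carbon, 1 nitrogen; one six-membered aromatic ring with 1 hetero atom), on an oxygen on an aromatic ring. Of the two measured steps, only a 1.5-fold higher number from compound 1 to compound 3 (0.16 log units; within the scatter) concerns the same place, the oxygen on the aromatic ring, where the whole (pyridin-3-yl)oxy group was exchanged for methoxymethyl, and that step stayed within the scatter. The other step, a 2.9-fold lower number from compound 1 to compound 2 (0.47 log units; beyond the scatter), is a bromo in place of hydrogen on an aromatic carbon and says nothing about the oxygen-bound group. With a single relevant precedent showing no movement, no step beyond the scatter is expected in this assay from compound 1 to compound 4; if anything, a slightly higher number is guessed, in line with compound 3. Compound 4 is therefore estimated at 25000 nM, with a range from 10000 nM to 60000 nM. For compound 4 this means an expected step of a 1.1-fold higher number from compound 1 to compound 4 (0.06 log units; within the scatter).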

Compound 4, half-maximal cytotoxic concentration: 73000 nM
Compound 4: middle estimate off by 2.9-fold (0.47 log units), on the low side; the whole stated range lies below it.
By their numbers in this assay, from the lowest: compound 2; then compounds 1 and 3 (each within the scatter of the next); then compound 4.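

In this assay, the group on the oxygen on the aromatic ring can move the read-out beyond the scatter: the exchange of pyridin-3-yl for the group of 10 heavy atoms gives a 3.3-fold higher number from compound 1 to compound 4 (0.52 log units; beyond the scatter), which means lower toxicity in this test. The earlier change at this place, methoxymethyl in place of the whole (pyridin-3-yl)oxy group, gave only a 1.5-fold higher number from compound 1 to compound 3 (0.16 log units; within the scatter), so that exchange alone did not show this place to be responsive, and the new step runs opposite to the one seen on the aromatic carbon, a 2.9-fold lower number from compound 1 to compound 2 (0.47 log units; beyond the scatter). Nothing available on these compounds accounts for the rise, so it stands as an observation on this single pair.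

The compounds shown do not separate the contribution of the entering ring from that of the chain that joins it to the oxygen, so it remains open whether a shorter or longer chain, or a simple amine or carboxylic acid at the end of the chain in place of the ring, would keep the higher number. Also open, from the compounds shown here alone, is whether the bromo step would carry over when the group of compound 4 is present on the oxygen.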